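The compounds below may be only part of what the source reports. "The series", "measured", "known", "first", "only" and "open" are said of these compounds alone.

The measured compounds are compound 1, `Cc1csc2cc([C@H](C)Nc3ncnc(N)c3C#N)c(-c3cccc(CN(C)CCCCN(C)Cc4ccccc4)c3)c(=O)n12`, and compound 2, `Cc1csc2cc([C@H](C)Nc3ncnc(N)c3C#N)c(-c3cccc(CN(C)CCCN(C)Cc4ccc(Cl)cc4)c3)c(=O)n12`. In an ADME assay on the whole organism (lung, Rattus norvegicus) for metabolic stability, read by LC-MS, with a stated time of 24 h (a higher number here means that more of the compound is left, a lower number that less of the compound is left), compound 1 gives 7.4%, and compound 2 gives 3.3%. On the two numbers available compound 2 stands lowest, with compound 1 its nearest neighbour; the step of a number 4.1 percentage points lower from compound 1 to compound 2 (within the scatter) is within the scatter, so no order between them can be claimed.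

Compound 3, `Cc1csc2cc([C@H](C)Nc3ncnc(N)c3C#N)c(-c3cccc(CN(C)CCCN4C[C@@H](C)O[C@@H](C)C4)c3)c(=O)n12`, has not yet been measured. It differs from compound 2 as follows: 2,6-dimethylmorpholin-4-yl in place of (4-chlorobenzyl)(methyl)amino on a saturated chain carbon, three bonds along the chain from an amine nitrogen. Among the measured compounds shown here, no measured step covers this exchange. For the measured compounds named here, the only step known, a number 4.1 percentage points lower from compound 1 to compound 2 (within the scatter), concerns a different change and was within the scatter, so it offers no guide to direction. The account therefore expects no step beyond the scatter in this assay, with a number 1.7 percentage points higher from compound 2 to compound 3 (within the scatter) as the estimated step. Compound 3 is expected to give 5%, between 0.5% and 15%.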

Compound 3, percent of the compound remaining: 0.8%
Beside the measured number, compound 3's estimate is 4.2 percentage points above it, within the range that was stated.
By their numbers in this assay, from the lowest: compounds 3, 2 and 1 (each within the scatter of the next).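

In this assay, 2,6-dimethylmorpholin-4-yl in place of (4-chlorobenzyl)(methyl)amino gives a number 2.5 percentage points lower from compound 2 to compound 3 (within the scatter) and, set against the group of compound 1, a number 6.6 percentage points lower from compound 1 to compound 3 (within the scatter). The position, on a saturated chain carbon three bonds along the chain from an amine nitrogen, therefore takes a non-aromatic ring with 2 hetero atoms in place of a six-membered aromatic ring of carbon only, with no step beyond the scatter in either comparison. Nothing in hand gives a reason for this reading.

As far as these compounds go, whether any group at this chain end can move the number beyond the scatter stays open, for instance a piperidine, an unsubstituted morpholine or a carboxylic acid. Also open, from the compounds shown here alone, is whether the two methyl groups and the two defined stereocentres of the entering ring have any bearing on the number.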